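This account rests on a few compounds, and the source may have more. Where it says the series, first, only, none or still open, it means among the compounds named here.

Compound 1, whose structure is `CC(C)N1CC[C@H](NC(=O)c2cc(-c3ccc(NS(=O)(=O)c4cccc(Cl)c4Cl)cc3)nc3[nH]ncc23)C1`, is the stronger of the two measured compounds in an assay for inhibition of serine/threonine-protein kinase Sgk1 (Homo sapiens), with stated times of 30 min and 60 min, in the presence of a further agent that is not named here (a lower number here means a stronger inhibitor, a higher number a weaker inhibitor), where compound 1 gives 38 nM. Among the compounds with values here, compound 2, with the structure `CN(C)CCCNC(=O)c1cc(-c2ccc(NS(=O)(=O)c3cccc(Cl)c3Cl)cc2)nc2[nH]ncc12`, gives 633 nM in this assay, and the only step that has been measured, a 17-fold higher number from compound 1 to compound 2 (1.22 log units; beyond the scatter), shows that exchanging the ring-bearing group on the amide-type nitrogen for the 3-(dimethylamino)propyl chain cost a great deal. Compound 3, with the structure `CCN1CCC(CNC(=O)c2cc(-c3ccc(NS(=O)(=O)c4cccc(Cl)c4Cl)cc3)nc3[nH]ncc23)C1`, has not yet been measured in this assay. It differs from compound 1 as follows: (1-ethylpyrrolidin-3-yl)methyl in place of 1-isopropylpyrrolidin-3-yl on an amide-type nitrogen. Within the data shown here, this change keeps the pyrrolidine ring and its single acceptor that compound 2 lost, so the measured step from compound 1 to compound 2 bears on it only loosely; it marks the upper end of what a rearrangement at this nitrogen has cost so far, while the change to compound 3 is much gentler. A weakening that is small, perhaps within the scatter, is therefore expected for compound 3, and the step of a 2.1-fold higher number from compound 1 to compound 3 (0.32 log units; beyond the scatter) is what is estimated. Compound 3 is expected to give about 80 nM in this assay, with a range from 30 nM to 250 nM.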

Compound 3, half-maximal inhibitory concentration: 109 nM
The estimate for compound 3 lay 1.4-fold (0.13 log units) below the measured number; the range from low to high includes it.
By their numbers in this assay, from the lowest: compound 1; then compound 3; then compound 2.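

Compound 1 and compound 3 carry the same atoms, and both groups hold one five-membered non-aromatic ring, so a 2.9-fold higher number from compound 1 to compound 3 (0.46 log units; beyond the scatter) shows that this amide-type nitrogen responds to how those atoms are joined and not only to which atoms are present. The step of a 5.8-fold lower number from compound 2 to compound 3 (0.76 log units; beyond the scatter) adds a second reading at the same place: with 1-ethylpyrrolidin-3-yl in place of 2-(dimethylamino)ethyl on the saturated chain carbon, much of the gap between compound 2 and compound 1 is closed, though compound 3 still remains apart from compound 1 beyond the scatter. No measured property of these groups is available to explain either step.

The change from compound 1 to compound 3 moves the ring away from the amide-type nitrogen by one saturated chain carbon, replaces isopropyl with ethyl and gives up the defined stereocentre, and the compounds shown do not separate these contributions. From the compounds shown here alone, a 1-ethylpyrrolidin-3-yl group directly on that nitrogen, a (1-isopropylpyrrolidin-3-yl)methyl group or a 1-isopropylpiperidin-4-yl group would each bear on that question, and how the opposite stereocentre of compound 1 behaves also remains open.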